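The source may report more compounds than this note shows. Statements on the series, on what has been measured and on what is new or still open speak of the compounds shown alone.

Working notes on the series in a functional assay for antagonist activity at 5-hydroxytryptamine receptor 4 (Rattus norvegicus); on this read-out lower numbers stand for lower potency and higher numbers for higher potency (the scale is a negative logarithm). Two compounds carry numbers. Compound 1 `COc1ccc(COc2cc(N)c(Cl)cc2C(=O)CCCCN2CCCCC2)cc1` gives 8.4 in this assay. Compound 2 `COc1cc(COc2cc(N)c(Cl)cc2C(=O)CCCCN2CCC(C)CC2)cc(OC)c1` gives 8.3 in this assay. The two values lie within the usual scatter of one another, so compound 2 sits at the same level as compound 1 on the numbers shown; no step between measured compounds is available, and the data give nothing on the size of any change within the series.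

Compound 3 `COc1cc(COc2cc(N)c(Cl)cc2C(=O)CCCCN2CCC(OC)CC2)cc(OC)c1` is the next compound, not yet measured. It differs from compound 2 in one place: methoxy in place of methyl on a saturated ring carbon.

For compound 3 the step from compound 2, no change at the digits printed from compound 2 to compound 3 (within the scatter), is expected to be none beyond the scatter, since the two measured compounds give no indication of how this assay responds to a change on the saturated ring. Compound 3 is estimated at 8.3 in this assay, with a range from 7.7 to 8.9.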

Compound 3, negative logarithm of the antagonist equilibrium constant: 8.4
Compound 3: the middle estimate sits 0.10 log units below what was measured; the range from low to high includes it.
By their numbers in this assay, from the lowest: compounds 2, 1 and 3 (each within the scatter of the next).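

In this assay, for the compounds shown here, the change from 4-methylpiperidin-1-yl to 4-methoxypiperidin-1-yl gives a number 0.10 log units higher from compound 2 to compound 3 (within the scatter) and is the first step that can be read at a single place. On a saturated ring carbon, three ring bonds from the ring nitrogen, methoxy can therefore stand in place of methyl with no change beyond the scatter, even though it brings an oxygen and a hydrogen-bond acceptor. Nothing measured here gives a reason for this outcome.

Going by these compounds, whether a carboxylic acid, an amine or a longer chain such as butoxy on this ring carbon would stay at the same level remains open. Compound 1 differs from compound 2 and compound 3 in more than one place, so steps from it cannot be read.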